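Chain homologation on the ring amine: microsomal clearance notes

The source may report more compounds than this note shows. Statements on the series, on what has been measured and on what is new or still open speak of the compounds shown alone.

Compound 1 `CCN1CC[C@H](NC(=O)C[C@@H]2C(=O)NC=CN2S(=O)(=O)c2ccc(C)cc2)C(C)(C)C1`: < 50 mL.min-1.g-1
Compound 2 `CCCN1CC[C@H](NC(=O)C[C@@H]2C(=O)NC=CN2S(=O)(=O)c2ccc(C)cc2)C(C)(C)C1`: < 50 mL.min-1.g-1

In an in vitro ADME assay on microsomes from liver (Homo sapiens) for pharmacokinetics (on this read-out lower numbers stand for slow clearance and higher numbers for fast clearance), compound 1 gives < 50 mL.min-1.g-1, a limit of the assay rather than a number. Compound 2 gives < 50 mL.min-1.g-1, likewise a limit. The step that the two limits leave unreadable from compound 1 to compound 2 is therefore hidden, since both values sit at the limit of < 50 mL.min-1.g-1 in this assay, at which 2 of the 2 values shown sit. Compound 2 thus stands at the slow-clearance end of the read-out shown, with no number inside the range.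

Compound 3 `Cc1ccc(S(=O)(=O)N2C=CNC(=O)[C@H]2CC(=O)N[C@H]2CCN(CC(C)C)CC2(C)C)cc1` differs from compound 2 by methyl in place of hydrogen on a saturated chain carbon bound to two saturated chain carbons. For the measured compounds named here, the one measured step that bears on this change gave no readable size, so no step beyond the scatter is expected here. Compound 3 is expected to give 35 mL.min-1.g-1 in this assay, with a range from 12 mL.min-1.g-1 to 75 mL.min-1.g-1. The step that the limit leaves unreadable from compound 2 to compound 3 is estimated to be small or absent, and a further limit read-out is the most likely result.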

Compound 3, intrinsic clearance in microsomes: 27 mL.min-1.g-1
Compound 3: the middle estimate sits 1.3-fold (0.11 log units) above what was measured; the range from low to high includes it.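

No step to compound 3 can be read from compound 1 or compound 2, because both of those compounds give only a limit: the limit of < 50 mL.min-1.g-1 in this assay, at which 2 of the 3 values shown sit.

The compounds shown leave open whether going from propyl to isobutyl on the ring amine changes the read-out in this assay at all.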